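The compounds below may be only part of what the source reports. "The series", "measured", "known", "first", "only" and "open" are said of these compounds alone.

Measured compounds:
compound 1 `CCOC(=O)C1=C(C)N/C(=C/c2cc(C)n(-c3cccc(C(F)(F)F)c3)c2C)C1=O`: 97 mL.min-1.g-1
compound 2 `CCOC(=O)C1=C(C)N/C(=C/c2cc(C)n(-c3ccc(SC)cc3)c2C)C1=O`: 66 mL.min-1.g-1

In an ADME assay on microsomes from liver (Mus musculus) for metabolic stability, read by LC-MS, tested at 1 uM (a higher number here means faster removal of the compound, a lower number slower removal), compound 1 gives 97 mL.min-1.g-1 and compound 2 gives 66 mL.min-1.g-1. Within the data shown here, these are the only two numbers so far, and the one measured step, a 1.5-fold lower number from compound 1 to compound 2 (0.17 log units; within the scatter), lies within the scatter, so compound 2 and compound 1 cannot be told apart on this read-out.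

Compound 3 `CCOC(=O)C1=C(C)N/C(=C/c2cc(C)n(-c3cccnc3)c2C)C1=O` is the next member. Its change from compound 2 is pyridin-3-yl in place of 4-(methylsulfanyl)phenyl on an aromatic nitrogen. Among the measured compounds shown here, the only measured step that bears on it is the swap of the aryl group on the same aromatic nitrogen, a 1.5-fold lower number from compound 1 to compound 2 (0.17 log units; within the scatter), which did not move the number beyond the scatter. Nothing in the data separates one aryl group on that nitrogen from another in this assay. The expectation for compound 3 is therefore a step of about a 1.2-fold lower number from compound 2 to compound 3 (0.08 log units; within the scatter), that is no change beyond the scatter in either direction. Compound 3 is estimated at 55 mL.min-1.g-1, with a range from 25 mL.min-1.g-1 to 120 mL.min-1.g-1.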

Compound 3, intrinsic clearance in microsomes: 82 mL.min-1.g-1
For compound 3 the middle estimate is 1.5-fold (0.17 log units) below the measured one; the measured number falls inside the stated range.
By their numbers in this assay, from the lowest: compounds 2, 3 and 1 (each within the scatter of the next).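

In this assay, pyridin-3-yl on the aromatic nitrogen gives a 1.2-fold higher number from compound 2 to compound 3 (0.09 log units; within the scatter), and against the other aryl group it gives a 1.2-fold lower number from compound 1 to compound 3 (0.07 log units; within the scatter). This position now carries three different aryl groups, two with a ring of carbon only and one with a hetero atom in the ring, and the three compounds cannot be told apart on this read-out, so neither the ring nitrogen nor the smaller heavy-atom count of pyridin-3-yl relative to 4-(methylsulfanyl)phenyl separates them here. No measurement at hand offers an explanation for how closely these numbers sit.

Still open, from the compounds shown here alone, is whether a group of a different kind on this nitrogen, such as a plain methyl, a longer alkyl chain or a chain ending in an amine, would move the number beyond the scatter. All three compounds shown also carry the same ethyl ester on the shared core, so they say nothing about how a carboxylic acid or an amide in its place would behave in this assay.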